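Swapping a Benzyl for a Phenoxy Group: Solubility Outlook

The source may report more compounds than this note shows. Statements on the series, on what has been measured and on what is new or still open speak of the compounds shown alone.

Of the compounds shown here, three sharing one core have been measured in a physicochemical assay for solubility, with a stated time of 18 h, at pH 7.4; on this read-out higher numbers stand for higher solubility and lower numbers for lower solubility. Compound 1 `COc1ccc(F)cc1CNCCCNc1ccnc2cc(Cc3cc(C)cc(C)c3)ccc12` gives 4200 nM. Compound 2 `COc1ccc(F)cc1CNCCCNc1ccnc2cc(C3CCCCC3)ccc12` gives 4200 nM, and compound 3 `COc1cccc(CNCCCNc2ccnc3cc(Cc4ccccc4)ccc23)c1O` gives 4200 nM. Going by the values given here, all three sit level on this assay, and the only step between compounds that differ in a single place, cyclohexyl in place of 3,5-dimethylbenzyl on an aromatic carbon, is no change at the digits printed from compound 1 to compound 2 (within the scatter).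

Compound 4 `COc1cccc(CNCCCNc2ccnc3cc(Oc4ccccc4)ccc23)c1O` has not yet been measured. It differs from compound 3 by phenoxy in place of benzyl on an aromatic carbon. Among the compounds with values here, the one step available, from compound 1 to compound 2, changed the group on the same kind of aromatic carbon and left solubility where it was; no measured pair bears directly on exchanging benzyl for phenoxy, so there is no firm basis for expecting movement in either direction.

The expectation is therefore that the step of no change at the digits printed from compound 3 to compound 4 (within the scatter) stays within the usual scatter. Within the data shown here, compound 4 is estimated to give 4200 nM in this assay, with a likely range from 2000 nM to 9000 nM, because compound 3 gives 4200 nM and no step among compounds 1, 2 and 3 has moved the read-out.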

Compound 4, solubility: 14500 nM
The estimate for compound 4 lay 3.5-fold (0.54 log units) below the measured number; measured number outside the range, above it.
By their numbers in this assay, from the lowest: compounds 1, 2 and 3 (each within the scatter of the next); then compound 4.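

At this aromatic carbon in this assay, phenoxy in place of benzyl gives a 3.5-fold higher number from compound 3 to compound 4 (0.54 log units; beyond the scatter), so the read-out at this position can respond to a change, which the earlier compounds had not shown, since cyclohexyl in place of 3,5-dimethylbenzyl gave no change at the digits printed from compound 1 to compound 2 (within the scatter). The new step also comes from a small exchange: benzyl and phenoxy both have 7 heavy atoms and one six-membered aromatic ring of carbon only, and they differ in that phenoxy has 6 carbons and 1 oxygen, with 1 hydrogen-bond acceptor where benzyl has none. Nothing measured here accounts for the higher number, so the reason for the step remains unknown.

On these data alone, it remains open whether the step is specific to phenoxy, or whether an anilino group, a phenylthio group or a benzoyl group at the same carbon would also separate from benzyl. As far as these compounds go, it is also open whether phenoxy gives a similar step on the compound 1 side chain, which carries a fluorine and a methoxy group, since this single pair tests the exchange only with the side chain of compound 3.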